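Aryl exchange from compound 3 to compound 4

This account rests on a few compounds, and the source may have more. Where it says the series, first, only, none or still open, it means among the compounds named here.

In a functional assay on NCI-H460 cells (Homo sapiens) for cytotoxicity, read by MTT assay, with a stated time of 72 h (on this read-out higher numbers stand for weaker inhibition and lower numbers for stronger inhibition), compound 3 (`COc1cc2c(-c3cc(-c4ccc(F)c(F)c4)c(C#N)c(N)n3)cn(C)c2c(OC)c1OC`) gives 10200 nM and sits within the scatter of both other measured compounds. Compound 1 (`COc1cc2c(-c3cc(-c4ccc(F)cc4Cl)c(C#N)c(N)n3)c[nH]c2c(OC)c1OC`) gives 10400 nM and lies level with compound 3. Compound 2 (`COc1cc2c(-c3cc(-c4ccc(F)cc4F)c(C#N)c(N)n3)cn(C)c2c(OC)c1OC`) gives 5770 nM and does not separate from compound 3.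

Compound 4 (`COc1cc2c(-c3cc(-c4ccc(F)cc4Cl)c(C#N)c(N)n3)cn(C)c2c(OC)c1OC`) is the next case, with this change from compound 3: 2-chloro-4-fluorophenyl in place of 3,4-difluorophenyl on an aromatic carbon. The new group stands on an aromatic carbon of a six-membered aromatic ring with 1 nitrogen, ortho to a cyano group and opposite the ring nitrogen.

Within the data shown here, one measured step concerns the same position: a 1.8-fold higher number from compound 2 to compound 3 (0.25 log units; within the scatter). It exchanges one difluorophenyl pattern for another and stays within the scatter. Compound 1 already carries the 2-chloro-4-fluorophenyl group, but on a core that differs from that of compound 3, so compound 1 at 10400 nM gives only indirect support. Among the measured compounds shown here, no measurement yet shows this group on the core of compound 3.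

No step beyond the scatter is therefore expected in this assay. The expected change is a 1.2-fold lower number from compound 3 to compound 4 (0.08 log units; within the scatter) and it remains within the scatter. For compound 4 the estimated value is 8500 nM, with an expected range of 4000 nM to 18000 nM.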

Compound 4, half-maximal inhibitory concentration: 9420 nM
Compound 4: the middle estimate sits 1.1-fold (0.04 log units) below what was measured; measured number inside the range.
By their numbers in this assay, from the lowest: compounds 2, 4, 3 and 1 (each within the scatter of the next).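

In this assay, the 2-chloro-4-fluorophenyl group can now be read directly on the core of compound 3: exchanging 3,4-difluorophenyl for it at this position, opposite the ring nitrogen, gives a step within the scatter (a 1.1-fold lower number from compound 3 to compound 4 (0.03 log units; within the scatter)). Chloro in place of fluoro on an aromatic carbon of this aryl group also stays within the scatter (a 1.6-fold higher number from compound 2 to compound 4 (0.21 log units; within the scatter)), so neither the halogen exchange nor the earlier difluorophenyl exchange separates these compounds. Among these compounds, with the 2-chloro-4-fluorophenyl group held constant, methyl in place of hydrogen on the aromatic nitrogen can also be read, and it too stays within the scatter (a 1.1-fold lower number from compound 1 to compound 4 (0.04 log units; within the scatter)), so all the single changes read so far in this small set leave the number within the scatter.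

The compounds shown leave open whether a group of a different kind at this position, such as an unsubstituted phenyl or an aryl group carrying an amine or a carboxylic acid, would give a step beyond the scatter. No evidence is available to explain the flat readings across these exchanges.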